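The source may report more compounds than this note shows. Statements on the series, on what has been measured and on what is new or still open speak of the compounds shown alone.

Measured in a functional assay on B16-F0 cells (Mus musculus) for inhibition, read by CCK-8 assay, with a stated time of 48 h; a lower number here means a stronger inhibitor, a higher number a weaker inhibitor:
- compound 1 `COc1cc(-c2ccnc3cc(-c4c[nH]c5ccccc45)nn23)cc(OC)c1OC`: 40 nM
- compound 2 `COc1cc(-c2ccnc3cc(-c4ccc5cc[nH]c5c4)nn23)cc(OC)c1OC`: 55 nM

Going by the values given here, compound 2, at 55 nM, lies within the scatter of compound 1, the only other compound measured. The next compound, compound 3 `COc1cc(-c2ccnc3cc(-c4ccc(C(C)=O)cc4)nn23)cc(OC)c1OC`, departs from compound 2 as follows: 4-acetylphenyl in place of 1H-indol-6-yl on an aromatic carbon. In words, 4-acetylphenyl stands in place of 1H-indol-6-yl on an aromatic carbon.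

Among the compounds with values here, only one measured step bears on this: a 1.4-fold higher number from compound 1 to compound 2 (0.14 log units; within the scatter). That step stayed within the scatter, but it only exchanged one indolyl group for another. Within the data shown here, no measured step replaces an indolyl group with a group of another kind, so it offers weak guidance here. A moderate move toward a higher number in this assay is expected, with wide uncertainty. The estimated change is a 2.7-fold higher number from compound 2 to compound 3 (0.44 log units; beyond the scatter). Compound 3 is expected at 150 nM, within an estimated range of 40 nM to 600 nM.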

Compound 3, half-maximal inhibitory concentration: 3930 nM
The estimate for compound 3 lay 26-fold (1.42 log units) below the measured number; measured number above the stated range.
By their numbers in this assay, from the lowest: compounds 1 and 2 (each within the scatter of the next); then compound 3.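

In this assay, the position on the five-membered aromatic ring proves far from indifferent to its substituent: changing an indolyl group to 4-acetylphenyl gives a 71-fold higher number from compound 2 to compound 3 (1.85 log units; beyond the scatter) and a 98-fold higher number from compound 1 to compound 3 (1.99 log units; beyond the scatter), both far larger than the step between the two indolyl attachments. The change removes the fused five-membered ring and the hydrogen-bond donor and adds a carbonyl with a hydrogen-bond acceptor, so these compounds cannot show which of these differences accounts for the loss. No supporting measurement explains the size of these steps.

From the compounds shown here alone, it remains open whether the acetyl group itself or the absence of the indole drives the result, a question that a plain phenyl group could address. A 1-methylindol-6-yl group could likewise test the role of the indole hydrogen.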